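A few compounds are considered here, and "the series" means these few. Any claim that something is new, unique, unknown or untested is made for them only; others in the source may bear on it.

Of the compounds shown here, two built on a shared core have been measured in an assay for positive allosteric modulation of metabotropic glutamate receptor 3 (Rattus norvegicus); on this read-out higher numbers stand for an effect only at larger amounts of compound and lower numbers for an effect already at smaller amounts. Compound 1 `Cc1c(OC[C@@H](C)COc2ccc(Cl)c(C(=O)O)c2)ccc(C(=O)CC(C)(C)C)c1O` gives 2200 nM. Compound 2 `COc1cc(C(=O)O)ccc1OC[C@H](C)COc1ccc(C(=O)CC(C)(C)C)c(O)c1C` gives 512 nM, the lower of the two numbers, and the gap between compound 2 and compound 1 lies beyond the usual scatter of repeated measurements. Compound 3 `Cc1c(OC[C@@H](C)COc2ccc(C(=O)O)cc2F)ccc(C(=O)CC(C)(C)C)c1O` has not yet been measured. It differs from compound 2 in one place: fluoro in place of methoxy on an aromatic carbon. Among the compounds with values here, no two measured compounds differ in only one place, so there is no measured step of comparable kind to lean on; the two numbers in hand show only that compound 1 and compound 2 give different results. For compound 3 a modest rise in the number is expected, a step of a 2.0-fold higher number from compound 2 to compound 3 (0.29 log units; within the scatter), resting on the structural change alone. Compound 3 is therefore estimated at 1000 nM, within a range from 300 nM to 3500 nM.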

Compound 3, half-maximal effective concentration: 1300 nM
For compound 3 the middle estimate is 1.3-fold (0.11 log units) below the measured one, within the range that was stated.
By their numbers in this assay, from the lowest: compound 2; then compounds 3 and 1 (each within the scatter of the next).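

In this assay the change from methoxy to fluoro, on an aromatic carbon ortho to a large group and meta to a carboxy group, gives a 2.5-fold higher number from compound 2 to compound 3 (0.40 log units; beyond the scatter) and so provides the first measured one-place step, showing that the group at this position can shift the number beyond the scatter. The other step, a 1.7-fold lower number from compound 1 to compound 3 (0.23 log units; within the scatter) stays within the scatter, so 4-carboxy-2-fluorophenyl in place of 3-carboxy-4-chlorophenyl does not separate these two compounds on this read-out. Nothing measured here bears on what lies behind the difference between methoxy and fluoro.

The compounds shown leave open how an ethoxy group, a hydroxy group or an amine on this same aromatic carbon would compare with methoxy and fluoro. Also open, on these data alone, is whether the step from methoxy to fluoro would keep its size with an amide in place of the carboxylic acid.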